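From a Trifluoromethylphenyl Amine to a Cyclopentyl Amine

This account rests on a few compounds, and the source may have more. Where it says the series, first, only, none or still open, it means among the compounds named here.

Of the compounds shown here, three sharing one core have been measured in a functional assay on MCF7 cells (Homo sapiens) for inhibition, read by sulforhodamine B assay; a higher number here means a weaker inhibitor, a lower number a stronger inhibitor.

Compound 1 `O=C1C=C(Nc2ccc(I)cc2)C(=O)c2c1nc1n2[C@H]2OC[C@@H](O)[C@H]2OC1` gives 2230 nM.
Compound 2 `Cc1ccc(NC2=CC(=O)c3nc4n(c3C2=O)[C@H]2OC[C@@H](O)[C@H]2OC4)cc1` gives 1660 nM.
Compound 3 `O=C1C=C(Nc2ccc(C(F)(F)F)cc2)C(=O)c2c1nc1n2[C@H]2OC[C@@H](O)[C@H]2OC1` gives only a limit, > 4000 nM.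

For the measured compounds named here, compound 3 is the one compound whose result is a limit rather than a number (the limit of > 4000 nM in this assay, at which 1 of the 3 values shown sits). Compound 4 `O=C1C=C(NC2CCCC2)C(=O)c2c1nc1n2[C@H]2OC[C@@H](O)[C@H]2OC1` has not been measured; it differs from compound 3 in one place: cyclopentyl in place of 4-(trifluoromethyl)phenyl on an amine nitrogen.

The measured steps all change a group on the aromatic ring while keeping the ring: a 1.3-fold lower number from compound 1 to compound 2 (0.13 log units; within the scatter), an at least 1.7-fold higher number from compound 1 to compound 3 (0.25 log units; that floor lies within the scatter) and an at least 2.4-fold higher number from compound 2 to compound 3 (0.38 log units; beyond the scatter). None of them replaces the ring itself, so none bears directly on the change to compound 4, and the two aromatic steps that exceeded the scatter point in no single direction for a change of a different kind. The expectation for compound 4 therefore rests mainly on the limit of compound 3 and is uncertain. In this assay compound 4 is estimated at 4000 nM, within 1000 nM to 16000 nM, with a result again at the limit considered about as likely as not. The expected step is a number no higher from compound 3 to compound 4 (the limit leaves the size open).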

Compound 4, half-maximal inhibitory concentration: > 16000 nM
Compound 4: a limit, no number (the forecaster's own chance of this, stated with the estimate: 50%); at least 4.0-fold (0.60 log units) between middle value and limit.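

In this assay compound 4 gives only a limit, not a number: the limit of > 16000 nM in this assay, at which 1 of the 4 values shown sits. This is the first change shown that removes the aromatic ring from the amine nitrogen, and replacing the ring with cyclopentyl gives an at least 9.6-fold higher number from compound 2 to compound 4 (0.98 log units; beyond the scatter) and an at least 7.1-fold higher number from compound 1 to compound 4 (0.85 log units; beyond the scatter). Compounds 1 and 2 therefore keep measurable inhibition with their aromatic rings, whereas compound 3 goes against any simple rule that an aromatic ring is enough, and its step to compound 4 cannot be read, as both results are limits.

The compounds shown leave open whether the loss of aromatic character or the change in ring size matters more. A plain phenyl ring, a cyclohexyl ring or an open butyl chain on the same nitrogen would help separate these possibilities.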